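Series notes: the substituent on the triazole chain carbon

A few compounds are considered here, and "the series" means these few. Any claim that something is new, unique, unknown or untested is made for them only; others in the source may bear on it.

Compound 1 `COc1ccc([C@@H]2CC(=O)c3c(O)cc(OCc4cn(Cc5cccc(C(F)(F)F)c5)nn4)cc3O2)cc1O` is the reference point. Going by the values given here, in a functional assay on RAW264.7 cells (Mus musculus) for inhibition, read by Griess assay, with stated times of 2 h and 24 h (a lower number here means a stronger inhibitor, a higher number a weaker inhibitor), compound 1 gives 19900 nM, the highest of the two numbers so far; its nearest neighbour is compound 2 `COc1ccc([C@@H]2CC(=O)c3c(O)cc(OCc4cn(C)nn4)cc3O2)cc1O`, which in this assay gives 15200 nM. Among the compounds with values here, the one step between them, a 1.3-fold lower number from compound 1 to compound 2 (0.12 log units; within the scatter), removes the whole arene from the saturated chain carbon bound to an aromatic nitrogen and leaves the number where it was.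

Compound 3 `CCCCn1cc(COc2cc(O)c3c(c2)O[C@H](c2ccc(OC)c(O)c2)CC3=O)nn1` is not yet measured. It differs from compound 1 as follows: propyl in place of 3-(trifluoromethyl)phenyl on a saturated chain carbon bound to an aromatic nitrogen. Within the data shown here, the only step that bears on this is the one from compound 1 to compound 2, where dropping the entire 3-(trifluoromethyl)phenyl moved nothing beyond the scatter. Replacing that group by propyl sits between those two extremes, so no step beyond the scatter is expected in this assay, in either direction; the expected step is a 1.2-fold lower number from compound 1 to compound 3 (0.07 log units; within the scatter). Compound 3 is therefore estimated at 17000 nM in this assay, with a likely range from 8000 nM to 36000 nM.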

Compound 3, half-maximal inhibitory concentration: 13900 nM
Estimate against measurement, compound 3: 1.2-fold (0.09 log units) above; low and high end bracket the measured number.
By their numbers in this assay, from the lowest: compounds 3, 2 and 1 (each within the scatter of the next).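

Propyl at this place, on a saturated chain carbon bound to an aromatic nitrogen, adds a point of a different kind in this assay: the step gives a 1.4-fold lower number from compound 1 to compound 3 (0.16 log units; within the scatter) and, against the bare end of the range, a 1.1-fold lower number from compound 2 to compound 3 (0.04 log units; within the scatter) as well. The earlier step compared only the two extremes, whereas these steps show that a plain alkyl chain also cannot be told apart from either of them, so neither the aromatic ring with its trifluoromethyl nor the propyl separates the three compounds in this assay, and the same holds for the change read one bond further out, 3-(trifluoromethyl)benzyl to butyl. Nothing at hand explains why compound 1, compound 2 and compound 3 read alike.

From the compounds shown here alone, all three groups carry no hydrogen-bond donors or acceptors, so it stays open whether an amine, a carboxylic acid or a much longer chain at this place would produce a step beyond the scatter. Going by these compounds, it also stays open whether changes elsewhere on the shared core, rather than at this place, would move the number at all.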